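Pyridine carboxamide series: rat microsome clearance, ether to alkyl swap

This account rests on a few compounds, and the source may have more. Where it says the series, first, only, none or still open, it means among the compounds named here.

Compound 1 `O=C(N[C@@H]1CCCC[C@H]1O)c1cnc(OC2CCC2)c(-c2ccc(Cl)cc2)c1`: 0.21 mL/min/kg
Compound 2 `O=C(N[C@@H]1CCCC[C@H]1O)c1cnc(OCC2CC2)c(-c2ccc(F)cc2)c1`: 0.037 mL/min/kg

In an ADME assay (liver) for pharmacokinetics, with Liver microsome (Rattus norvegicus) as the target, read by LC-MS, using microsomes, tested at 2 uM (on this read-out lower numbers stand for slow clearance and higher numbers for fast clearance), compound 1 gives 0.21 mL/min/kg, the highest of the two numbers measured, while compound 2 gives 0.037 mL/min/kg, a gap beyond the scatter. Compound 3 `O=C(N[C@@H]1CCCC[C@H]1O)c1cnc(CCC2CC2)c(-c2ccc(Cl)cc2)c1` has not been measured. It differs from compound 1 by 2-cyclopropylethyl in place of cyclobutyloxy on an aromatic carbon. Among the measured compounds shown here, no measured pair isolates this change, so the expectation rests on compound 1 alone. The step of a 1.4-fold higher number from compound 1 to compound 3 (0.15 log units; within the scatter) is expected to be small and upward, near the edge of the scatter. Compound 3 is estimated to give 0.3 mL/min/kg, within 0.1 mL/min/kg to 0.9 mL/min/kg.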

Compound 3, clearance: 1.5 mL/min/kg
Estimate against measurement, compound 3: 5.0-fold (0.70 log units) below; the measured number lies above the stated range.
By their numbers in this assay, from the lowest: compound 2; then compound 1; then compound 3.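

In this assay, among the compounds shown here, 2-cyclopropylethyl in place of cyclobutyloxy, on the aromatic carbon next to the ring nitrogen, gives a 7.1-fold higher number from compound 1 to compound 3 (0.85 log units; beyond the scatter) and this is the only single-place step so far. This position therefore matters for the read-out, since a change that keeps the heavy-atom count and loses the oxygen and its hydrogen-bond acceptor moves the number beyond the scatter. Nothing in hand accounts for the rise. The step rests on one pair, so it may not hold on other cores of the series. Going by these compounds, whether an amine or a longer ether chain here would read closer to compound 1 or compound 3 stays open.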